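This account rests on a few compounds, and the source may have more. Where it says the series, first, only, none or still open, it means among the compounds named here.

Measured compounds in a functional assay on SV5A8 cells (Homo sapiens) for cytotoxicity; on this read-out lower numbers stand for stronger inhibition and higher numbers for weaker inhibition:

Compound 1 `Cc1ccc2c(NCc3ccc(NC(=O)C4CCN(Cc5ccc(Cl)cc5)CC4)cc3)nc(N(C)C)nc2c1`. In this assay compound 1 gives > 3180 nM, which is a limit of the assay and not a number.
Compound 2 `Cc1ccc2c(NCc3ccc(NC(=O)C4CCN(Cc5cccc(F)c5)CC4)cc3)nc(N(C)C)nc2c1`. In this assay compound 2 gives > 4170 nM, again only a limit of the assay.
Compound 3 `Cc1ccc2c(NCc3ccc(NC(=O)C4CCN(Cc5ccccc5)CC4)cc3)nc(N3CCN[C@@H](C)C3)nc2c1`. In this assay compound 3 gives > 8860 nM, also a limit of the assay.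

Compound 2 thus stands as a limit only, and the two further values shown are limits as well (the limit of > 3180 nM in this assay, at which 1 of the 3 values shown sits, (the limit of > 4170 nM in this assay, at which 1 of the 3 values shown sits), (the limit of > 8860 nM in this assay, at which 1 of the 3 values shown sits)), so no order among the three compounds can be read.

Compound 4 `Cc1ccc2c(NCc3ccc(NC(=O)C4CCN(Cc5ccccc5F)CC4)cc3)nc(N(C)C)nc2c1` differs from compound 2 in one place: 2-fluorophenyl in place of 3-fluorophenyl on a saturated chain carbon bound to an amine nitrogen in a ring. Going by the values given here, the one measured step that bears on a change of this kind is a step that the two limits leave unreadable from compound 1 to compound 2; its size is not readable, both ends being limits. Nothing measured therefore points to a step beyond the scatter in this assay in either direction, and the most likely outcome is another limit.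

Compound 4 is expected near 5000 nM, with a range from 2000 nM to 20000 nM. The expected step is a step that the limit leaves unreadable from compound 2 to compound 4, that is, none beyond the scatter.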

Compound 4, half-maximal inhibitory concentration: > 6670 nM
Compound 4: no number, only a limit (the forecaster's own chance of this, stated with the estimate: 80%); at least 1.3-fold (0.12 log units) between middle value and limit.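

In this assay compound 4 gives > 6670 nM, a limit of the assay and not a number. The steps to compound 4 from compound 1 and from compound 2 cannot be read, as all three values are limits. The compounds shown leave open whether 4-chlorophenyl, 3-fluorophenyl and 2-fluorophenyl differ at all in this assay.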